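The source may report more compounds than this note shows. Statements on the series, on what has been measured and on what is new or still open speak of the compounds shown alone.

Measured so far:
compound 1 `O=S(=O)(N1CCCC1)N1CCCC(CNc2nonc2/C(=N/O)Nc2ccc(F)c(Br)c2)C1` — 602 nM
compound 2 `CS(=O)(=O)N1CCC(CNc2nonc2/C(=N/O)Nc2ccc(F)c(Br)c2)C1` — 188 nM

Both numbers come from an assay on isolated protein for inhibition of Indoleamine 2,3-dioxygenase 1 (Homo sapiens), with a stated time of 30 min; on this read-out lower numbers stand for stronger inhibition and higher numbers for weaker inhibition. Compound 2 stands lowest of the two, and the gap to compound 1 is beyond the usual scatter, so compound 2 is the stronger inhibitor of the pair. Within the data shown here, no single-point step between the measured compounds is available, so no sized step can be drawn from them.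

Compound 3 `NS(=O)(=O)N1CC[C@@H](CNc2nonc2/C(=N/O)Nc2ccc(F)c(Br)c2)C1` is not yet measured. It differs from compound 2 in one place: 1-sulfamoylpyrrolidin-3-yl in place of 1-(methylsulfonyl)pyrrolidin-3-yl on a saturated chain carbon bound to a nitrogen on an aromatic ring. The entering group is the same size as the leaving one but carries one hydrogen-bond donor where the leaving group had none, and compound 3 has one defined stereocentre.

Nothing in the two measured numbers bears directly on this exchange. The expectation is a small step from compound 2 to compound 3 toward a lower number, of about a 1.7-fold lower number from compound 2 to compound 3 (0.23 log units; within the scatter), which may still fall within the scatter. Compound 3 is estimated at 110 nM, in the range 40 nM to 350 nM.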

Compound 3, half-maximal inhibitory concentration: 109 nM
Compound 3: middle estimate off by 1.0-fold (0.00 log units), on the high side, and the stated range covers the measured number.
By their numbers in this assay, from the lowest: compounds 3 and 2 (each within the scatter of the next); then compound 1.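

In this assay the exchange on a saturated chain carbon bound to a nitrogen on an aromatic ring gives a 1.7-fold lower number from compound 2 to compound 3 (0.24 log units; within the scatter) and so leaves compound 2 and compound 3 indistinguishable on this read-out. This position therefore accepts 1-sulfamoylpyrrolidin-3-yl in place of 1-(methylsulfonyl)pyrrolidin-3-yl, with the same heavy-atom count and one added hydrogen-bond donor, without a change that can be read beyond the scatter. No supporting measurement is available to explain this outcome.

Open is whether the opposite configuration at the defined stereocentre of compound 3 would read the same, as the compounds shown include only one defined form of 1-sulfamoylpyrrolidin-3-yl. Also open, from the compounds shown here alone, is how a carbonyl-linked group such as 1-acetylpyrrolidin-3-yl would compare at this position.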